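A few compounds are considered here, and "the series" means these few. Any claim that something is new, unique, unknown or untested is made for them only; others in the source may bear on it.

Measured so far:
- Compound 1 `Oc1nc(-c2ccccc2)cc2ccccc12`: 2450 nM
- Compound 2 `Oc1nc(-c2ccc(C(F)(F)F)cc2)cc2ccccc12`: 87300 nM

In a functional assay on SK-OV-3 cells (Homo sapiens) for cytotoxicity (a higher number here means a weaker inhibitor, a lower number a stronger inhibitor), compound 2 has the higher number of the two, at 87300 nM. Compound 3 `Cc1ccc(-c2cc3ccccc3c(O)n2)cc1` differs from it by one group: methyl in place of trifluoromethyl on an aromatic carbon. Among the measured compounds shown here, only one measured step bears on this change: a 36-fold higher number from compound 1 to compound 2 (1.55 log units; beyond the scatter), a large step beyond the scatter, which came with trifluoromethyl in place of hydrogen. For the measured compounds named here, no methyl compound has been measured, but much of that step should be reversed, so a large move to a lower number is expected. The expected step is a 15-fold lower number from compound 2 to compound 3 (1.16 log units; beyond the scatter). The estimate for compound 3 is 6000 nM, with an expected range of 1500 nM to 30000 nM.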

Compound 3, half-maximal inhibitory concentration: 13800 nM
Compound 3: the middle estimate sits 2.3-fold (0.36 log units) below what was measured; measured number inside the range.
By their numbers in this assay, from the lowest: compound 1; then compound 3; then compound 2.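

At this place on the ring, para to a large group, methyl also gives a weaker result than hydrogen, with a 5.6-fold higher number from compound 1 to compound 3 (0.75 log units; beyond the scatter) in this assay, so the loss seen earlier does not belong to trifluoromethyl alone. Replacing trifluoromethyl with methyl recovers only part of that loss, with a 6.3-fold lower number from compound 2 to compound 3 (0.80 log units; beyond the scatter), and methyl therefore falls between the other two groups. Nothing available here explains the order of these groups.

Both groups tested at this place give higher numbers than hydrogen. From the compounds shown here alone, whether any group can give a lower number remains open, and a methoxy group, an amine or a single fluorine atom would test this.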